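Compound 3 to compound 4: fluoro in place of methoxy

The source may report more compounds than this note shows. Statements on the series, on what has been measured and on what is new or still open speak of the compounds shown alone.

In a functional assay on HL-60 cells (Homo sapiens) for cytotoxicity, read by WST assay, with a stated time of 48 h (a higher number here means that more compound is needed for the effect, a lower number that less compound is needed), compound 3 `COc1ccc(C[C@H]2COC(=O)[C@@H]2Cc2ccc(Cl)c(Cl)c2)cc1` gives 37000 nM, level with compound 2 `O=C1OC[C@H](Cc2ccc(O)cc2)[C@H]1Cc1ccc(Cl)c(Cl)c1` at 37000 nM. Compound 1 `O=C1OC[C@H](Cc2cccc(O)c2)[C@H]1Cc1ccc(Cl)c(Cl)c1` gives 48000 nM, within the scatter of both.

Compound 4 `O=C1OC[C@H](Cc2ccc(F)cc2)[C@H]1Cc1ccc(Cl)c(Cl)c1` carries fluoro in place of methoxy on an aromatic carbon, para to a large group: fluoro in place of methoxy on an aromatic carbon.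

For the measured compounds named here, no fluoro compound has been measured, so the evidence is indirect. The nearest steps are no change at the digits printed from compound 2 to compound 3 (within the scatter), a 1.3-fold lower number from compound 1 to compound 2 (0.11 log units; within the scatter) and a 1.3-fold lower number from compound 1 to compound 3 (0.11 log units; within the scatter), all within the scatter. No step beyond the scatter is therefore expected in this assay.

The expected step is a 1.1-fold lower number from compound 3 to compound 4 (0.02 log units; within the scatter). For compound 4 the estimated value is 35000 nM, with an expected range of 18000 nM to 70000 nM.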

Compound 4, half-maximal effective concentration: 14000 nM
Compound 4: the middle estimate sits 2.5-fold (0.40 log units) above what was measured; measured number below the stated range.
By their numbers in this assay, from the lowest: compound 4; then compounds 2, 3 and 1 (each within the scatter of the next).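

At the aromatic carbon para to a large group, hydroxy and methoxy could not be told apart in this assay, but fluoro gives a 2.6-fold lower number from compound 3 to compound 4 (0.42 log units; beyond the scatter) and a 2.6-fold lower number from compound 2 to compound 4 (0.42 log units; beyond the scatter). The step from the 3-hydroxyphenyl compound is of similar kind, at a 3.4-fold lower number from compound 1 to compound 4 (0.54 log units; beyond the scatter). For the compounds shown here, this place therefore responds to the group it carries, and fluoro is the first change here to move beyond the scatter.

Nothing available accounts for the lower number. From the compounds shown here alone, whether chloro, trifluoromethyl or an amine on this carbon would follow fluoro or stay with hydroxy and methoxy remains open.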